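Notes on the step from compound 2 to compound 3

The source may report more compounds than this note shows. Statements on the series, on what has been measured and on what is new or still open speak of the compounds shown alone.

Measured so far:
compound 1 (`O=C(OCCCC(c1ccc(F)cc1)c1ccc(F)cc1)c1cc(Cl)c(OCc2ccccc2)c(Cl)c1`): > 20000 nM
compound 2 (`O=C(NCCCCC(c1ccc(F)cc1)c1ccc(F)cc1)Nc1ccc(C(F)(F)F)cc1`): 2780 nM

In a functional assay on MDA-MB-231 cells (Homo sapiens) for cytotoxicity, read by MTT assay, with a stated time of 48 h (on this read-out lower numbers stand for stronger inhibition and higher numbers for weaker inhibition), compound 1 gives > 20000 nM as a limit of the assay, not a number. Going by the values given here, compound 2 gives 2780 nM in this assay and so holds the only numerical value so far. Compound 1 and compound 2 differ in more than one place, so their two values are not read as a step.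

The next compound, compound 3 (`CC(=O)Nc1cc(NC(=O)NCCCCC(c2ccc(F)cc2)c2ccc(F)cc2)ccc1Cl`), keeps the rest of compound 2 and carries 3-acetamido-4-chlorophenyl in place of 4-(trifluoromethyl)phenyl on an amide-type nitrogen. Among the compounds with values here, no measured step covers this replacement, so the expectation rests on compound 2 alone, with 2780 nM as its anchor. A modest weakening is expected in this assay, and the estimated change is a 1.8-fold higher number from compound 2 to compound 3 (0.25 log units; within the scatter) in size, which may not clear the usual scatter by much. For compound 3 the estimated value is 5000 nM with an expected range from 1800 nM to 18000 nM in this read-out.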

Compound 3, half-maximal inhibitory concentration: 9120 nM
Beside the measured number, compound 3's estimate is 1.8-fold (0.26 log units) below it, within the range that was stated.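

In this assay, 3-acetamido-4-chlorophenyl in place of 4-(trifluoromethyl)phenyl on the amide-type nitrogen gives a 3.3-fold higher number from compound 2 to compound 3 (0.52 log units; beyond the scatter). Going by these compounds alone, this is the first step that can be read between two numbers, and it shows that the read-out responds to the group at this position by more than the usual scatter. The change is not a single one: the entering group brings a hydrogen-bond donor, a hydrogen-bond acceptor and a chlorine, and the three fluorines leave, so this one step does not assign the shift to any of these parts. Compound 1 remains the only entry held at a limit of the assay, not a number: the limit of > 20000 nM in this assay, at which 1 of the 3 values shown sits.

Which part of 3-acetamido-4-chlorophenyl carries the step remains open, and a comparison of the chlorine and the acetamido group each alone on the phenyl ring at this position would separate them. Also open, on these data alone, is how a basic amine or a carboxylic acid on that ring would read in this assay.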